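A Charged Five-Membered Ring Replaces a Methylphenyl Group

The compounds below may be only part of what the source reports. "The series", "measured", "known", "first", "only" and "open" are said of these compounds alone.

Two compounds share one core: compound 1 `O=C(Nc1ccc2nc(NC(=O)C3CCCCC3)sc2c1)c1cccc(Oc2ccccc2)c1` and compound 2 `Cc1ccc(C(=O)Nc2ccc3nc(NC(=O)C4CCCCC4)sc3c2)cc1`. In a functional assay on WI-38 VA13 cells (Homo sapiens) for cytotoxicity (a higher number here means that more compound is needed for the effect, a lower number that less compound is needed), compound 1 gives > 4 ug/mL, which is a limit of the measurement rather than a number. In this assay, within the data shown here, compound 2 gives 5.1 ug/mL, the only number among the values so far. Compound 3 `Cc1[nH][n+](C)c(C)c1C(=O)Nc1ccc2nc(NC(=O)C3CCCCC3)sc2c1` has not yet been tested; it differs from compound 2 (a group of 8 heavy atoms (6 carbon, 2 nitrogen; one five-membered aromatic ring with 2 hetero atoms) in place of a group of 7 heavy atoms (7 carbon; one six-membered aromatic ring of carbon only), on a carbonyl carbon). Among the measured compounds shown here, no step between measured compounds is available to guide this change. Compound 3 is expected to give 6 ug/mL, within 3 ug/mL to 12 ug/mL. The expected step of a 1.2-fold higher number from compound 2 to compound 3 (0.07 log units; within the scatter) is small, near the edge of the usual scatter.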

Compound 3, half-maximal effective concentration: 0.012 ug/mL
For compound 3 the middle estimate is 500-fold (2.70 log units) above the measured one, outside the stated range (below it).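

In this assay the group on the carbonyl carbon proves decisive, since replacing 4-methylphenyl with the charged five-membered ring gives a 430-fold lower number from compound 2 to compound 3 (2.63 log units; beyond the scatter) in the amount of compound needed for the effect. Compound 1 offers only a limit, > 4 ug/mL, so it cannot show how far this position can shift the value. Nothing shown explains why the step is so large.

From the compounds shown here alone, whether the charge or the ring carries the step remains open. So does what a longer chain ending in an amine, or a carboxylic acid, would give here.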